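Oxazolyl for Imidazolylmethyl at the Branch Carbon

The compounds below may be only part of what the source reports. "The series", "measured", "known", "first", "only" and "open" are said of these compounds alone.

compound 1 `CC(C)C(Cc1ncc[nH]1)c1ccc(-c2ccc3cccc(F)c3c2)[nH]c1=O`: 11 nM
compound 2 `CCn1ncc2c(F)cc(-c3ccc(C(CC)(CC)c4nnc[nH]4)c(=O)[nH]3)cc21`: 17 nM

Within the data shown here, in an assay on CHO cells for displacement of a labelled ligand from prostaglandin E2 receptor EP3 subtype (Homo sapiens), read by radioligand binding (a lower number here means a stronger inhibitor, a higher number a weaker inhibitor), compound 1 gives 11 nM, the lowest of the two numbers so far, while compound 2 gives 17 nM; the gap lies within the scatter, so neither is set above the other. Compound 3 `CC(C)C(c1ncco1)c1ccc(-c2ccc3cccc(F)c3c2)[nH]c1=O` is a variant of compound 1; the change is 1,3-oxazol-2-yl in place of (1H-imidazol-2-yl)methyl on a saturated chain carbon bound to an aromatic carbon and a saturated chain carbon. Among the measured compounds shown here, no measured pair shows this exact step, so its size is open. Compound 2 also carries a five-membered aromatic ring bound directly to the chain carbon and gives 17 nM, which suggests such a direct attachment is tolerated. The step also removes a hydrogen-bond donor, for which no comparison is at hand. A modest weakening is expected, roughly a 2.7-fold higher number from compound 1 to compound 3 (0.44 log units; beyond the scatter). For compound 3 the estimated value is 30 nM, with a range from 8 nM to 120 nM.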

Compound 3, inhibition constant: 24 nM
Estimate against measurement, compound 3: 1.3-fold (0.10 log units) above; low and high end bracket the measured number.
By their numbers in this assay, from the lowest: compounds 1, 2 and 3 (each within the scatter of the next, the first and the last beyond it).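

In this assay, placing 1,3-oxazol-2-yl in place of (1H-imidazol-2-yl)methyl on a saturated chain carbon bound to an aromatic carbon and a saturated chain carbon gives a 2.2-fold higher number from compound 1 to compound 3 (0.34 log units; beyond the scatter) and so puts a first size on this exchange. The step lies beyond the scatter, so the position does respond to the change, but only modestly. The entering group has no hydrogen-bond donor, and compound 3 still gives 24 nM on the core of compound 1, so binding of this order does not depend on the donor of the leaving group.

Ring and link change together in this step, so it remains open whether 1H-imidazol-2-yl bound directly to the chain carbon, or 1,3-oxazol-2-ylmethyl, would separate the two effects. Nothing available explains the size of the step.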